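Swapping diethylamino for a plain amino group

A few compounds are considered here, and "the series" means these few. Any claim that something is new, unique, unknown or untested is made for them only; others in the source may bear on it.

compound 1 `CN1CCN(CC(=O)NC2CC3(N4CCCC4)CC(c4ccccc4)C2C(c2ccccc2)C3)CC1`: 50200 nM
compound 2 `CN1CCN(CC(=O)OC2CC3(N4CCCC4)CC(c4ccccc4)C2C(c2ccccc2)C3)CC1`: 24600 nM
compound 3 `CCN(CC)CC(=O)OC1CC2(N3CCCC3)CC(c3ccccc3)C1C(c1ccccc1)C2`: 49000 nM

In an ADME assay on L6 cells (Rattus norvegicus) for cytotoxicity, read by resazurin assay, with a stated time of 72 h (a lower number here means a stronger inhibitor, a higher number a weaker inhibitor), compound 3 gives 49000 nM and sits within the scatter of both other compounds. The two comparisons show a 1.0-fold lower number from compound 1 to compound 3 (0.01 log units; within the scatter) and a 2.0-fold higher number from compound 2 to compound 3 (0.30 log units; within the scatter). For the measured compounds named here, the only step beyond the scatter is modest, with a 2.0-fold lower number from compound 1 to compound 2 (0.31 log units; beyond the scatter).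

The next compound is compound 4 `NCC(=O)OC1CC2(N3CCCC3)CC(c3ccccc3)C1C(c1ccccc1)C2`, which keeps the ester and the shared core of compound 3. The structural change is amino in place of diethylamino on a saturated chain carbon bound to a carbonyl carbon.

The closest guide is the earlier swap at that same place, which gave a 2.0-fold higher number from compound 2 to compound 3 (0.30 log units; within the scatter). Going by the values given here, that swap did not involve a plain amino group, and no measured compound carries one, so this is an extrapolation from thin data. Given that small step, no shift beyond the scatter is expected in this assay, although the uncertainty is wide. The estimated change is a 1.2-fold lower number from compound 3 to compound 4 (0.09 log units; within the scatter). Compound 4 is expected to give about 40000 nM, with an estimated range from 15000 nM to 100000 nM.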

Compound 4, half-maximal inhibitory concentration: 42900 nM
Estimate against measurement, compound 4: 1.1-fold (0.03 log units) below; measured number inside the range.
By their numbers in this assay, from the lowest: compounds 2, 4, 3 and 1 (each within the scatter of the next, the first and the last beyond it).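

In this assay, cutting diethylamino down to a plain amino group on the saturated chain carbon bound to a carbonyl carbon removes all the carbon of that group and adds a hydrogen-bond donor, yet the result is a 1.1-fold lower number from compound 3 to compound 4 (0.06 log units; within the scatter). The same holds for amino in place of the ring-bearing 4-methylpiperazin-1-yl, with a 1.7-fold higher number from compound 2 to compound 4 (0.24 log units; within the scatter), and for the wider change that also replaces the amide link with the ester, with a 1.2-fold lower number from compound 1 to compound 4 (0.07 log units; within the scatter). So the earlier compounds showed only that two substituted amines gave similar numbers here, while compound 4 extends this to the smallest amine in the set, although no evidence is available to explain this lack of response.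

Going by these compounds, a carboxylic acid at this place, with no amine at all, is not covered by these compounds, so it remains open whether the nitrogen matters to the number. On these data alone, a longer chain between the carbonyl and the amino group also remains untested here, as does the plain amino group on the amide-linked version of the core.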